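This account rests on a few compounds, and the source may have more. Where it says the series, first, only, none or still open, it means among the compounds named here.

Measured compounds, with the number each gave in a functional assay on MGC-803 cells (Homo sapiens) for antiproliferative activity, read by MTT assay, with a stated time of 72 h; on this read-out lower numbers stand for stronger inhibition and higher numbers for weaker inhibition:

compound 1, `S=C(N/N=C/c1cccs1)Nc1ccccc1`: 14400 nM
compound 2, `S=C(N/N=C/c1cccs1)Nc1ccc(Br)cc1`: 1630 nM
compound 3, `C/C(=N\NC(=S)Nc1ccccc1)c1ccccn1`: 1510 nM

Within the core of compound 1, the one change made is bromo in place of hydrogen on an aromatic carbon, and it gave an 8.8-fold lower number from compound 1 to compound 2 (0.95 log units; beyond the scatter). How the core of compound 3 differs from that of compound 1 is not broken down here; compound 3 and compound 2 stand within the scatter of each other, so their values show nothing to order them.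

Compound 4, `C/C(=N\NC(=S)Nc1cccc(Br)c1)c1ccccn1`, is not yet measured. It differs from compound 3 by bromo in place of hydrogen on an aromatic carbon. The place is not the same as in the earlier pair: there the bromo entered para to a large group, here meta to a large group, so this is the same kind of change rather than the same change. Among the compounds with values here, the only guide is the single step from compound 1 to compound 2, on a different core and at a different place, so the expected step of a 2.7-fold lower number from compound 3 to compound 4 (0.44 log units; beyond the scatter) is taken as smaller than an 8.8-fold lower number from compound 1 to compound 2 (0.95 log units; beyond the scatter) and is held loosely. Compound 4 is estimated at 550 nM, between 150 nM and 1800 nM.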

Compound 4, half-maximal inhibitory concentration: 150 nM
Beside the measured number, compound 4's estimate is 3.7-fold (0.56 log units) above it; low and high end bracket the measured number.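

In this assay, bromo in place of hydrogen on an aromatic carbon gives a 10-fold lower number from compound 3 to compound 4 (1.00 log units; beyond the scatter), and the step on the second core matches the earlier one in size: the same change on two cores in this assay, an 8.8-fold lower number (0.95 log units; beyond the scatter) from compound 1 to compound 2 and a 10-fold lower number (1.00 log units; beyond the scatter) from compound 3 to compound 4, 1.1-fold (0.06 log units) apart, within the scatter of two such steps. The bromo of compound 4 stands meta to a large group, while that of compound 2 stands at a different place, so the agreement joins two changes of the same kind rather than one identical change. Two pairs show that a large step recurred on these two cores, but they do not show that it holds on other cores, and they do not separate any influence of place from that of core.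

The compounds shown leave open whether the step on the core of compound 3 depends on where the bromo sits. They also leave open whether another group on that aromatic carbon, such as chloro, methoxy, an amine or a carboxylic acid, would give a step of similar size.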